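Cytotoxicity of a benzisoxazolone analogue of compound 1

The source may hold more compounds than are shown below. What is called first, only, known or untested is meant among the compounds shown, and "the series" means these compounds.

Compound 1 `CC(C)(C)OC(=O)N(Cc1ccco1)C(=O)c1ccc(CN2Cc3ccccc3C2=O)cc1`: 95200 nM
Compound 2 `O=C(NCc1ccco1)c1ccc(CN2Cc3ccccc3C2=O)cc1`: > 100000 nM
Compound 3 `O=C(NCc1ccco1)c1ccc(Cn2sc3ccccc3c2=O)cc1`: > 100000 nM

Within the data shown here, compound 1 is the only compound of the three that gives a number in an ADME assay on RAW264.7 cells (Mus musculus) for cytotoxicity, read by WST assay; on this read-out higher numbers stand for lower toxicity in this test and lower numbers for higher toxicity in this test; in this assay compound 1 gives 95200 nM. For compound 2 this assay reports only a limit, > 100000 nM. For compound 3 as well this assay reports only a limit, > 100000 nM. Among the measured compounds shown here, the one step that can be counted, an at least 1.0-fold higher number from compound 1 to compound 2 (0.02 log units; that floor lies within the scatter), carries the hydrogen in place of the tert-butoxycarbonyl group on the amide-type nitrogen and does not leave the scatter, resting on (the limit of > 100000 nM in this assay, at which 2 of the 3 values shown sit).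

Compound 4 `CC(C)(C)OC(=O)N(Cc1ccco1)C(=O)c1ccc(Cn2oc3ccccc3c2=O)cc1` differs from compound 1 in another place: a group of 10 heavy atoms (7 carbon, 1 nitrogen, 2 oxygen; one five-membered aromatic ring with 2 hetero atoms, one six-membered aromatic ring of carbon only) in place of a group of 10 heavy atoms (8 carbon, 1 nitrogen, 1 oxygen; one five-membered non-aromatic ring with 1 hetero atom, one six-membered aromatic ring of carbon only), on a saturated chain carbon bound to an aromatic carbon. Compounds 2 and 3 differ from each other in that same region, and both sit at a limit, which shows nothing beyond that neither reached a number. For the measured compounds named here, no measured step bears on the change from compound 1 to compound 4 directly, so no step beyond the scatter is expected in this assay. Compound 4 is therefore estimated to give 100000 nM, within 50000 nM to 200000 nM, a step of a 1.1-fold higher number from compound 1 to compound 4 (0.02 log units; within the scatter) that is expected to stay within the scatter.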

Compound 4, concentration lethal to 50% of the cells: > 100000 nM
Compound 4: only a limit was reported; the forecaster's own chance of this, stated with the estimate: 60%; the middle value lies on the limit itself.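

With the tert-butoxycarbonyl group kept on the amide-type nitrogen, compound 4 gives a countable step at this place, which the pair of compound 2 and compound 3 could not give: on a saturated chain carbon bound to an aromatic carbon, the group with a five-membered aromatic ring with 2 hetero atoms replaces the group with a five-membered non-aromatic ring with 1 hetero atom, and this assay shows an at least 1.0-fold higher number from compound 1 to compound 4 (0.02 log units; that floor lies within the scatter). The value of compound 4, > 100000 nM, is a limit and not a number. The step therefore does not leave the scatter and separates the two groups at this place by no measurable amount, and what it can show is bounded: the limit of > 100000 nM in this assay, at which 3 of the 4 values shown sit.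

The compounds shown leave open how this assay would respond to an amine or a carboxylic acid on the shared core, and whether a longer chain in place of the saturated chain carbon would give a number clear of the limit. They also leave open what an acetyl group would do on the amide-type nitrogen in place of tert-butoxycarbonyl.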